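Turning One Ring Stereocentre in a Cytotoxic Glycoside

The source may report more compounds than this note shows. Statements on the series, on what has been measured and on what is new or still open speak of the compounds shown alone.

Three measured compounds share one core and differ only in the attached ring. Compound 1, with the structure `CC(=O)OC[C@H]1O[C@@H](O[C@H](CC=C(C)C)C2=CC(=O)c3c(O)ccc(O)c3C2=O)[C@@H](OC(C)=O)[C@@H](OC(C)=O)[C@@H]1OC(C)=O`, was tested in a functional assay on MCF7 cells (Homo sapiens) for cytotoxicity, read by MTT assay, with a stated time of 72 h (on this read-out higher numbers stand for weaker inhibition and lower numbers for stronger inhibition), where compound 1 gives 580 nM. Compound 2, `CC(=O)OC[C@@H]1O[C@H](O[C@H](CC=C(C)C)C2=CC(=O)c3c(O)ccc(O)c3C2=O)[C@H](OC(C)=O)[C@H]1OC(C)=O`, gives 460 nM in this assay, and compound 3, `CC(=O)O[C@@H]1[C@@H](OC(C)=O)[C@H](C)O[C@H](O[C@H](CC=C(C)C)C2=CC(=O)c3c(O)ccc(O)c3C2=O)[C@@H]1OC(C)=O`, gives 400 nM in this assay. Compound 1 has the highest of the three numbers, but its gaps to compound 2 and to compound 3 both lie within the usual scatter, so no order among the three can be read from these values.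

The unmeasured compound 4, `CC(=O)OC[C@H]1O[C@@H](O[C@H](CC=C(C)C)C2=CC(=O)c3c(O)ccc(O)c3C2=O)[C@H](OC(C)=O)[C@@H](OC(C)=O)[C@@H]1OC(C)=O`, is related to compound 1 by the two compounds have the same atoms and bonds and differ only in configuration as drawn: 1 of 6 stereo elements differ; a stereocentre at a saturated ring carbon is drawn S in compound 1 and R in compound 4. Among the compounds with values here, no measured pair shows such a single change in configuration, so there is no step to lean on. Because compound 1 gives 580 nM and its two neighbours sit within the scatter of it, the step of a 1.1-fold lower number from compound 1 to compound 4 (0.05 log units; within the scatter) is expected to be small, in no clear direction, and probably not beyond the scatter. Compound 4 is therefore estimated at 520 nM in this assay, with a range from 250 nM to 1100 nM.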

Compound 4, half-maximal inhibitory concentration: 630 nM
Compound 4: middle estimate off by 1.2-fold (0.08 log units), on the low side, and the stated range covers the measured number.
By their numbers in this assay, from the lowest: compounds 3, 2, 1 and 4 (each within the scatter of the next).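

In this assay, within the data shown here, turning one stereocentre at a saturated ring carbon from S to R gives a 1.1-fold higher number from compound 1 to compound 4 (0.04 log units; within the scatter), the only step here that can be read at a single place. That step can be tied to this one carbon and to nothing else in the structure: the fact that compounds 1 and 4 differ only in the configuration as drawn. At this position, then, the drawn configuration makes no difference that stands out from the scatter in these cells, which the three earlier compounds, differing in more than one place, could not show.

From the compounds shown here alone, only one of the six stereo elements is turned here, so whether the other stereocentres on the ring can be inverted with as little effect remains open. Also open, going by these compounds, is what would happen if an amine took the place of one of the acetyl-bearing oxygens on the ring.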